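Mirror Image of Compound 2

The source may hold more compounds than are shown below. What is called first, only, known or untested is meant among the compounds shown, and "the series" means these compounds.

Of the compounds shown here, two built on a shared core have been tested in an assay on isolated protein for inhibition of alpha-mannosidase (Canavalia ensiformis), tested at 1000 uM; on this read-out higher numbers stand for more inhibition at the one concentration tested (going by the name of the read-out) and lower numbers for less inhibition. Compound 1 `OC[C@@]1(c2ccc(F)cc2)NC[C@@H](O)[C@@H]1O` gives 6.6%. Compound 2 `OC[C@]1(c2ccc(O)cc2)NC[C@H](O)[C@H]1O` gives 3.4%. Compound 2 stands lowest of the two numbers, but its value and that of compound 1 lie within the usual scatter of the measurement, so no order between them can be claimed; both show only marginal inhibition at the single concentration tested.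

Compound 3 `OC[C@@]1(c2ccc(O)cc2)NC[C@@H](O)[C@@H]1O` is the next compound to be measured. Relative to compound 2 it differs in the two compounds have the same atoms and bonds and differ only in configuration as drawn: 3 of 3 stereo elements differ (all stereocentres are inverted: mirror images); a stereocentre at a saturated ring carbon is drawn S in compound 2 and R in compound 3; a stereocentre at a saturated ring carbon is drawn S in compound 2 and R in compound 3; a stereocentre at a saturated ring carbon is drawn S in compound 2 and R in compound 3. Compound 3 thereby carries the same drawn configuration as compound 1. Within the data shown here, no step between two measured compounds isolates such an inversion, so the effect of the change cannot be read from the data. Given that compound 1 and compound 2 both sit near the bottom of the read-out, the step of a number 2.6 percentage points higher from compound 2 to compound 3 (within the scatter) is expected to be small, in either direction, and not beyond the scatter. Compound 3 is estimated to give 6%, with a range from 0% to 16%.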

Compound 3, a percentage reported as inhibition, at one concentration (the size of the read-out at that concentration, not a potency): 2.2%
Compound 3: the middle estimate sits 3.8 percentage points above what was measured; low and high end bracket the measured number.
By their numbers in this assay, from the lowest: compounds 3, 2 and 1 (each within the scatter of the next).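

In this assay, among these compounds, the mirror-image pair gives the first direct comparison of the two drawn configurations of the shared core, with a number 1.2 percentage points lower from compound 2 to compound 3 (within the scatter) and so no difference that this read-out can resolve. Within the configuration drawn for compound 1, the swap of hydroxy in place of fluoro on an aromatic carbon gives a number 4.4 percentage points lower from compound 1 to compound 3 (within the scatter) and so no resolved difference either. Neither the full inversion nor this single exchange on the aromatic carbon therefore lifts any of the three compounds clear of the marginal inhibition seen at the one concentration tested, and the inversion result is a clean comparison of configuration alone: the fact that compounds 2 and 3 differ only in the configuration as drawn

The compounds shown leave open whether the two configurations would separate on a version of this core that inhibits clearly, and whether the mirror image of compound 1 would read like compound 1. They also leave open what an amine or a carboxylic acid in place of the hydroxy on the aromatic carbon would give in this assay on either configuration.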